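Methoxycarbonyl added to the core of compound 1

The source may report more compounds than this note shows. Statements on the series, on what has been measured and on what is new or still open speak of the compounds shown alone.

In an assay for inhibition of Tryptophan 2,3-dioxygenase (Homo sapiens), with stated times of 10 min and 60 min, tested at 100 uM (on this read-out lower numbers stand for a weaker effect and higher numbers for a stronger effect at the one concentration tested), compound 1 `O=[N+]([O-])c1ccccc1CNc1cccc2[nH]ncc12` gives 87%. Compound 2 `O=[N+]([O-])c1cc(Cl)ccc1CNc1cc(C(F)(F)F)cc2[nH]ncc12` gives 93% in this assay; the two values lie within the scatter of each other, so compound 1 stands on the same level as compound 2 and nothing separates them. Compound 3 `COC(=O)c1cc(NCc2ccccc2[N+](=O)[O-])c2cn[nH]c2c1` has not yet been tested in this assay. It differs from compound 1 by methoxycarbonyl in place of hydrogen on an aromatic carbon. Within the data shown here, no measured pair shows the effect of this change, so the step expected in this assay is a number 3 percentage points lower from compound 1 to compound 3 (within the scatter), a move not beyond the scatter in either direction. Compound 3 is estimated at 84%, within 62% to 98%.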

Compound 3, a percentage reported as inhibition, at one concentration (the size of the read-out at that concentration, not a potency): 20%
Compound 3: middle estimate off by 64 percentage points, on the high side; the measured number lies below the stated range.
By their numbers in this assay, from the lowest: compound 3; then compounds 1 and 2 (each within the scatter of the next).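

Methoxycarbonyl in place of hydrogen on this aromatic carbon of the core gives a number 67 percentage points lower from compound 1 to compound 3 (beyond the scatter) in this assay and is the first change at a single place that can be read in this series. The position is therefore not indifferent to substitution, at least for this group on the core of compound 1. No available measurement explains the loss.

On these data alone, whether the loss is specific to methoxycarbonyl remains open. A carboxylic acid, a primary amide or a methyl group on the same carbon would test how far it extends.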